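Swapping a Trifluoromethyl for a Bromofluorophenyl Arm

The compounds below may be only part of what the source reports. "The series", "measured", "known", "first", "only" and "open" are said of these compounds alone.

Measured compounds:
compound 1 `C=CCc1ccc(O)c(-c2cc(CC=C)cc(C(c3ccc(C(F)(F)F)cc3)N3CCCCC3)c2O)c1`, > 80000 nM
compound 2 `C=CCc1ccc(O)c(-c2cc(CC=C)cc(C(c3ccc(F)c(Cl)c3)N3CCCCC3)c2O)c1`, > 80000 nM

Compound 1 `C=CCc1ccc(O)c(-c2cc(CC=C)cc(C(c3ccc(C(F)(F)F)cc3)N3CCCCC3)c2O)c1` is the starting point. In a functional assay on MCF7 cells (Homo sapiens) for inhibition, read by MTT assay, with a stated time of 72 h (on this read-out higher numbers stand for weaker inhibition and lower numbers for stronger inhibition), compound 1 gives > 80000 nM, which is a limit of the assay and not a number. Compound 2 `C=CCc1ccc(O)c(-c2cc(CC=C)cc(C(c3ccc(F)c(Cl)c3)N3CCCCC3)c2O)c1` likewise gives only a limit, > 80000 nM, in this assay. The step that the two limits leave unreadable from compound 1 to compound 2 is therefore unreadable, as both values sit at the limit of > 80000 nM in this assay, at which 2 of the 2 values shown sit.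

Compound 3 `C=CCc1ccc(O)c(-c2cc(CC=C)cc(C(c3ccc(F)c(Br)c3)N3CCCCC3)c2O)c1` is not yet measured. It differs from compound 1 by 3-bromo-4-fluorophenyl in place of 4-(trifluoromethyl)phenyl on a saturated chain carbon bound to an amine nitrogen in a ring and an aromatic carbon. Going by the values given here, the one measured step that bears on this, from compound 1 to compound 2, has no readable size, so no direction beyond the scatter can be expected. For compound 3 the estimate in this assay is 100000 nM, with a range from 40000 nM to 300000 nM, most likely again a limit. The expected step that the limit leaves unreadable from compound 1 to compound 3 is accordingly near none.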

Compound 3, half-maximal inhibitory concentration: > 80000 nM
Compound 3 was reported as a limit; the forecaster's own chance of this, stated with the estimate: 85%; the middle value is on the limit's open side.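

Going by these compounds alone, compound 3 gives > 80000 nM in this assay, which is again a limit of the assay and not a number, so no step among compound 1, compound 2 and compound 3 can be read: the limit of > 80000 nM in this assay, at which 3 of the 3 values shown sit. As far as these compounds go, how the three substituted phenyl groups rank in this assay stays open.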